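Swapping the hydrazone aryl group: naphthol to dibromophenol

The source may report more compounds than this note shows. Statements on the series, on what has been measured and on what is new or still open speak of the compounds shown alone.

Measured compounds:
- compound 1 `CN(C)CCn1cnnc1-c1cc(Oc2ccc(NC(=O)N/N=C/c3c[nH]c4ccccc34)cc2F)ccn1`: 790 nM
- compound 2 `CN(C)CCn1cnnc1-c1cc(Oc2ccc(NC(=O)N/N=C/c3ccc(F)cc3F)cc2F)ccn1`: 810 nM
- compound 3 `CN(C)CCn1cnnc1-c1cc(Oc2ccc(NC(=O)N/N=C/c3c(O)ccc4ccccc34)cc2F)ccn1`: 2020 nM

In a functional assay on MKN-45 cells (Homo sapiens) for cytotoxicity, read by MTT assay, with a stated time of 72 h (on this read-out lower numbers stand for stronger inhibition and higher numbers for weaker inhibition), compound 3 gives the highest number of the three. The step of a 2.6-fold higher number from compound 1 to compound 3 (0.41 log units; beyond the scatter) and the step of a 2.5-fold higher number from compound 2 to compound 3 (0.40 log units; beyond the scatter) are both beyond the scatter, while the step of a 1.0-fold higher number from compound 1 to compound 2 (0.01 log units; within the scatter) is within it, so the two measured partners of compound 3 sit close together and compound 3 stands apart from them.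

Compound 4 `CN(C)CCn1cnnc1-c1cc(Oc2ccc(NC(=O)N/N=C/c3cc(Br)c(O)c(Br)c3)cc2F)ccn1` differs from compound 3 by one change: 3,5-dibromo-4-hydroxyphenyl in place of 2-hydroxynaphthalen-1-yl on a carbon with a double bond to nitrogen. Among the measured compounds shown here, no measured step carries this exact replacement. The nearest evidence is the pair of steps into compound 3, each of which moved the number up modestly when a 2-hydroxynaphthalen-1-yl group was introduced on the carbon with a double bond to nitrogen; removing that group in favour of a single six-membered ring with two bromines and a hydroxyl may reverse part of that move, but the dibromophenol is itself untested. Compound 4 is therefore expected to land between compound 3 and the other two, with the step of a 1.7-fold lower number from compound 3 to compound 4 (0.23 log units; within the scatter) expected to be small and downward. The estimate for compound 4 in this assay is 1200 nM, with a range from 500 nM to 3000 nM.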

Compound 4, half-maximal inhibitory concentration: 4320 nM
For compound 4 the middle estimate is 3.6-fold (0.56 log units) below the measured one; measured number above the stated range.
By their numbers in this assay, from the lowest: compounds 1 and 2 (each within the scatter of the next); then compound 3; then compound 4.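

At the carbon with a double bond to nitrogen, 3,5-dibromo-4-hydroxyphenyl gives the highest number of the four groups in this assay: a 2.1-fold higher number from compound 3 to compound 4 (0.33 log units; beyond the scatter), with larger steps of a 5.3-fold higher number from compound 2 to compound 4 (0.73 log units; beyond the scatter) and a 5.5-fold higher number from compound 1 to compound 4 (0.74 log units; beyond the scatter), so compound 4 is the weakest of the set. Ring count does not sort these numbers, as 2,4-difluorophenyl in compound 2 and 3,5-dibromo-4-hydroxyphenyl in compound 4 are both single rings yet lie at opposite ends of the series, while the two-ring 2-hydroxynaphthalen-1-yl in compound 3 falls in the middle. No measurement is available that accounts for this order.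

The compounds shown leave open whether the two bromines, the hydroxyl or their combination sets the number of compound 4, a question that a plain 4-hydroxyphenyl and a 3,5-dibromophenyl at this place would help to separate. From the compounds shown here alone, it also remains open how a ring carrying an amine or a carboxylic acid would read at this carbon.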